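Exchanging the Chain-End Group of Compound 3

The source may report more compounds than this note shows. Statements on the series, on what has been measured and on what is new or still open speak of the compounds shown alone.

Compound 3 `N#CNC(=N)NCCCCCn1nc(-c2ccccc2)ccc1=O` stands at the upper edge of what has been seen in a functional assay on the whole organism (stomach) with Rattus norvegicus as the target; on this read-out higher numbers stand for an effect only at larger amounts of compound and lower numbers for an effect already at smaller amounts. In this assay compound 3 gives > 100 mg/kg, which is a limit of the assay and not a number. Compound 1 `C/N=C(/NC#N)N(C)CCCCn1nc(-c2ccccc2)ccc1=O` gives the same kind of result: in this assay compound 1 gives > 100 mg/kg, again a limit rather than a number. Within the data shown here, only compound 2 `CC/N=C(\S)NCCCCn1nc(-c2ccccc2)ccc1=O` returns a number, 37.2 mg/kg in this assay; so (the limit of > 100 mg/kg in this assay, at which 2 of the 3 values shown sit), the step that the two limits leave unreadable from compound 1 to compound 3 cannot be read, and an at least 2.6-fold higher number from compound 2 to compound 3 (0.42 log units; beyond the scatter) is the one step that lies beyond the scatter.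

Compound 4 `CN(C)/C(=N/CCCCn1nc(-c2ccccc2)ccc1=O)NC#N` carries a group of 8 heavy atoms (4 carbon, 4 nitrogen; no ring) in place of a group of 7 heavy atoms (3 carbon, 4 nitrogen; no ring), on a saturated chain carbon, four bonds along the chain from an aromatic nitrogen. The step that the two limits leave unreadable from compound 1 to compound 3 exchanges groups of these same two sizes in the opposite direction and so bears on this change, yet both of its ends are limits and it gives no size. Among the measured compounds shown here, no other measured step touches this change. The expected step is a step that the limit leaves unreadable from compound 3 to compound 4, no shift that can be read beyond the scatter. Compound 4 is therefore expected to give 150 mg/kg in this assay, with a range from 40 mg/kg to 600 mg/kg, and most probably only a limit once more.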

Compound 4, dose for half-maximal effect: 30.3 mg/kg
Estimate against measurement, compound 4: 5.0-fold (0.69 log units) above; the measured number lies below the stated range.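

In this assay, the exchange gives an at least 3.3-fold lower number from compound 3 to compound 4 (0.51 log units; beyond the scatter), so the group of 8 heavy atoms at this saturated chain carbon can return a number where the group of 7 heavy atoms returned only a limit. The count of heavy atoms alone does not decide the outcome: two groups of 8 heavy atoms are separated by an at least 3.3-fold lower number from compound 1 to compound 4 (0.51 log units; beyond the scatter), while a 1.2-fold lower number from compound 2 to compound 4 (0.09 log units; within the scatter) leaves the sulfur-bearing group and this group within the scatter of each other. Compound 1 and compound 3 each sit at a limit of the assay, not at a number, so the full size of both steps from them stays unknown because of that limit: the limit of > 100 mg/kg in this assay, at which 2 of the 4 values shown sit.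

The compounds shown leave open whether a urea or a primary amine at this chain end would also return a number. They also leave open whether a longer chain carrying the group of compound 4 would keep it.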